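A longer chain on compound 2

The source may report more compounds than this note shows. Statements on the series, on what has been measured and on what is new or still open speak of the compounds shown alone.

Values in a physicochemical assay for solubility, at pH 7.4 (on this read-out higher numbers stand for higher solubility and lower numbers for lower solubility), for three compounds:
- compound 1 `Cc1cc(C(=O)N[C@H]2CC[C@@H](NC(=O)c3cc(F)cnc3Oc3cccc(-c4cccc(CN5C[C@@H](C)N[C@@H](C)C5)c4O)c3)CC2)nn1C` gives 470000 nM
- compound 2 `Cc1cc(C(=O)N[C@H]2CC[C@@H](NC(=O)c3cc(F)cnc3Oc3cccc(-c4ccc(CN5C[C@@H](C)N[C@@H](C)C5)cc4)c3)CC2)nn1C` gives 1300000 nM
- compound 3 `C[C@@H]1CN(Cc2ccc(-c3cccc(Oc4ncc(F)cc4C(=O)N[C@H]4CC[C@@H](NC(=O)c5cc6ccccn6n5)CC4)c3)cc2)C[C@H](C)N1` gives 580000 nM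

Of these three, compound 2 has the highest number. Compound 4 `Cc1cc(C(=O)N[C@H]2CC[C@@H](NC(=O)c3cc(F)cnc3Oc3cccc(-c4ccc(CCCN5C[C@@H](C)N[C@@H](C)C5)cc4)c3)CC2)nn1C` differs from compound 2 in one place: 2-(3,5-dimethylpiperazin-1-yl)ethyl in place of 3,5-dimethylpiperazin-1-yl on a saturated chain carbon bound to an aromatic carbon. In words, 2-(3,5-dimethylpiperazin-1-yl)ethyl stands in place of 3,5-dimethylpiperazin-1-yl on a saturated chain carbon bound to an aromatic carbon.

Within the data shown here, no measured step makes this same change. Among the measured compounds shown here, the only step available, a 2.2-fold lower number from compound 2 to compound 3 (0.35 log units; beyond the scatter), swaps a different group, on a carbonyl carbon, so it serves only as a rough yardstick for how far one change can move this assay. A step no larger than that one is expected here. With compound 2 at the top of the three at 1300000 nM, any expected move leans lower. The estimated step is a 1.6-fold lower number from compound 2 to compound 4 (0.21 log units; within the scatter). For compound 4 the estimated value is 800000 nM, with an expected range from 350000 nM to 1600000 nM.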

Compound 4, solubility: 130000 nM
For compound 4 the middle estimate is 6.2-fold (0.79 log units) above the measured one; the whole stated range lies above it.
By their numbers in this assay, from the lowest: compound 4; then compounds 1 and 3 (each within the scatter of the next); then compound 2.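

In this assay, among these compounds, lengthening the chain from (3,5-dimethylpiperazin-1-yl)methyl to 3-(3,5-dimethylpiperazin-1-yl)propyl gives a 10-fold lower number from compound 2 to compound 4 (1.00 log units; beyond the scatter) and so moves the number further than the one earlier step, the swap on a carbonyl carbon (a 2.2-fold lower number from compound 2 to compound 3 (0.35 log units; beyond the scatter)). The entering group keeps the same six-membered ring and the same counts of hydrogen-bond donors and acceptors, so these two compounds differ only in the length of the chain that carries the ring. Nothing shown here gives a reason for this drop.

The compounds shown give only two chain lengths, so it stays open whether a chain of intermediate length, 2-(3,5-dimethylpiperazin-1-yl)ethyl, would fall between them. On these data alone, it also stays open whether a longer chain still, 4-(3,5-dimethylpiperazin-1-yl)butyl, would lower the number further.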